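The compounds below may be only part of what the source reports. "The series", "measured", "known", "first", "only" and "open" are said of these compounds alone.

Measured compounds in the series:

compound 1, `Cc1nc(NC(C)C)c2cnn(-c3ccccc3)c2n1`: 32000 nM
compound 2, `CCc1nc(NC(C)C)c2cnn(-c3ccccc3)c2n1`: 38000 nM

In a functional assay on G-361 cells (Homo sapiens) for cytotoxicity, read by sulforhodamine B assay (on this read-out lower numbers stand for stronger inhibition of growth and higher numbers for weaker inhibition of growth), compound 1 gives 32000 nM and compound 2 gives 38000 nM. Going by the values given here, the single step between them, a 1.2-fold higher number from compound 1 to compound 2 (0.07 log units; within the scatter), does not separate the two. Compound 2 therefore holds the higher of the two numbers shown, but its nearest and only neighbour, compound 1, lies within the scatter of it, so no order between them can be claimed.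

Compound 3, `CC(C)NCc1nc(NC(C)C)c2cnn(-c3ccccc3)c2n1`, differs from compound 2 by isopropylamino in place of methyl on a saturated chain carbon bound to an aromatic carbon. Among the compounds with values here, the only measured step at this place is the one from compound 1 to compound 2, a small enlargement of the saturated chain that stayed within the scatter. Within the data shown here, the present change brings in a donor and an acceptor, which no measured step covers, so the measured data give no direction. The expectation is a number near that of compound 2, with a wide range to allow for the untested group. Compound 3 is estimated at 30000 nM, from 8000 nM to 100000 nM, an expected step of a 1.3-fold lower number from compound 2 to compound 3 (0.10 log units; within the scatter).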

Compound 3, concentration for 50% growth inhibition: > 100000 nM
Compound 3 ended at the assay's limit; the forecaster's own chance of this, stated with the estimate: 20%; middle value at least 3.3-fold (0.52 log units) away from the limit.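

In this assay compound 3 gives > 100000 nM, which is a limit of the assay and not a number: the limit of > 100000 nM in this assay, at which 1 of the 3 values shown sits.

At the saturated chain carbon bound to an aromatic carbon, isopropylamino in place of methyl gives an at least 2.6-fold higher number from compound 2 to compound 3 (0.42 log units; beyond the scatter), and isopropylamino in place of hydrogen gives an at least 3.1-fold higher number from compound 1 to compound 3 (0.49 log units; beyond the scatter). On these data alone, the earlier step at this place, a 1.2-fold higher number from compound 1 to compound 2 (0.07 log units; within the scatter), did not show that the place responds to what is attached, whereas both new steps lie beyond the scatter, towards weaker inhibition of growth, and their true size stays open at the limit.

The compounds shown leave open whether the step goes with the nitrogen of the entering group or with its size, as a carbon-only chain such as isobutyl would have the same reach without the nitrogen. They also leave open whether a smaller nitrogen group such as aminomethyl, or an oxygen group such as hydroxymethyl, would stay within the scatter of compound 2 or also move beyond it.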